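Nitrobenzyl for methylbenzyl on the fluorophenyl analogue

The compounds below may be only part of what the source reports. "The series", "measured", "known", "first", "only" and "open" are said of these compounds alone.

Compound 2 `Cc1ccc(Cn2cc(CO/N=C/c3c(-c4ccc(F)cc4)nc4ccc(Br)cn34)nn2)cc1` is measured in a functional assay on the whole organism (strain NMRI) with Mus musculus as the target, with a stated time of 4 h (a higher number here means that more compound is needed for the effect, a lower number that less compound is needed), and compound 2 gives 100 mg/kg. Compound 3 `Cc1ccc(Cn2cc(CO/N=C/c3c(-c4ccc(C)cc4)nc4ccc(Br)cn34)nn2)cc1` gives 100 mg/kg in this assay, and no change at the digits printed from compound 2 to compound 3 (within the scatter). Compound 1 `Cc1ccc(-c2nc3ccc(Br)cn3c2/C=N/OCc2cn(Cc3ccc([N+](=O)[O-])cc3)nn2)cc1` gives 20 mg/kg in this assay, the lowest dose of the three, so compound 2 stands together with compound 3 at the highest number of the three and apart from compound 1.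

Compound 4 `O=[N+]([O-])c1ccc(Cn2cc(CO/N=C/c3c(-c4ccc(F)cc4)nc4ccc(Br)cn34)nn2)cc1` is not yet measured in this assay. It differs from compound 2 by nitro in place of methyl on an aromatic carbon. Among the measured compounds shown here, one measured step bears directly on this change: a 5.0-fold higher number from compound 1 to compound 3 (0.70 log units; beyond the scatter), the same exchange run the other way, on the core carrying the 4-methylphenyl group in place of the 4-fluorophenyl group. Read in reverse it points to a lower number for compound 4, of about that size, since the fluoro-for-methyl exchange itself made no difference beyond the scatter. Compound 4 is therefore expected to give about 20 mg/kg in this assay, within 10 mg/kg to 50 mg/kg, an expected step of a 5.0-fold lower number from compound 2 to compound 4 (0.70 log units; beyond the scatter).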

Compound 4, minimum effective dose: 100 mg/kg
Compound 4: the middle estimate sits 5.0-fold (0.70 log units) below what was measured; measured number above the stated range.
By their numbers in this assay, from the lowest: compound 1; then compounds 2, 3 and 4 (each within the scatter of the next).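

On the fluorophenyl core in this assay, nitro in place of methyl gives no change at the digits printed from compound 2 to compound 4 (within the scatter), so the gain seen on the core of compound 1 does not carry over to this core. With the 4-nitrobenzyl group kept, fluoro in place of methyl gives a 5.0-fold higher number from compound 1 to compound 4 (0.70 log units; beyond the scatter), so in this series the lower dose appears only where nitro and methyl occur together, in compound 1. The effect of the nitro-for-methyl change at this position therefore depends on the group at the other end of the molecule: the same change on two cores in this assay, a 5.0-fold higher number (0.70 log units; beyond the scatter) from compound 1 to compound 3 and no change at the digits printed (within the scatter) from compound 4 to compound 2, 5.0-fold (0.70 log units) apart, beyond the scatter of two such steps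

On these data alone, this pairing rests on compound 1 alone, so it remains open whether a chloro or methoxy group in place of that methyl would also give the lower dose alongside 4-nitrobenzyl. As far as these compounds go, it is also open whether an amine or a carboxylic acid in place of the nitro would do the same.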